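Swapping the hydroxy-methoxyphenyl arm for a methylsulfanylphenyl

This account rests on a few compounds, and the source may have more. Where it says the series, first, only, none or still open, it means among the compounds named here.

Compound 1: `COc1ccc(C2=C(c3ccc(SC)cc3)CC3CCCN3C2=O)cc1O`, > 100000 nM
Compound 2: `COc1ccc(C2=C(c3ccc(SC)cc3)CC3CCCN3C2=O)cc1C`, 15000 nM
Compound 3: `CSc1ccc(C2=C(c3ccc(Br)cc3)C(=O)N3CCCC3C2)cc1`, 9000 nM
Compound 4: `CSc1ccc(C2=C(c3ccc(SC)cc3)C(=O)N3CCCC3C2)cc1`, not yet measured

In a functional assay on SK-OV-3 cells (Homo sapiens) for cytotoxicity (on this read-out lower numbers stand for stronger inhibition of growth and higher numbers for weaker inhibition of growth), compound 1 reaches only the limit (the limit of > 100000 nM in this assay, at which 1 of the 3 values shown sits), so its place is known only as a limit. Compound 4 differs from it in this way: 4-(methylsulfanyl)phenyl in place of 3-hydroxy-4-methoxyphenyl on a double-bonded ring carbon. The two steps that bear on this are the one in which the same arm is replaced, an at least 11-fold lower number from compound 1 to compound 3 (1.04 log units; beyond the scatter), and the one that removes the hydroxy, an at least 6.6-fold lower number from compound 1 to compound 2 (0.82 log units; beyond the scatter). Both point the same way, toward a lower number. Compound 4 is therefore expected to land near compound 3, since the step of a 1.7-fold lower number from compound 2 to compound 3 (0.22 log units; within the scatter) lay within the scatter. The estimate for compound 4 is 10000 nM, with a range from 3000 nM to 40000 nM, meaning an expected step of an at least 10-fold lower number from compound 1 to compound 4 (1.00 log units; beyond the scatter).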

Compound 4, concentration for 50% growth inhibition: 2000 nM
Estimate against measurement, compound 4: 5.0-fold (0.70 log units) above; measured number outside the range, below it.
By their numbers in this assay, from the lowest: compound 4; then compounds 3 and 2 (each within the scatter of the next). At a limit, above all of these: compound 1.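

In this assay compound 1 stands only at a limit, so an at least 50-fold lower number from compound 1 to compound 4 (1.69 log units; beyond the scatter) gives a bound on the change and not its size. The steps between measured values are firmer: a 4.5-fold lower number from compound 3 to compound 4 (0.65 log units; beyond the scatter), with methylsulfanyl in place of bromo on an aromatic carbon, and a 7.5-fold lower number from compound 2 to compound 4 (0.88 log units; beyond the scatter). Within the data shown here, compounds 2 and 3 lay within the scatter of each other, so compound 4 is the first here to stand clearly apart among the measured arms at this position.

From the compounds shown here alone, whether an ethylsulfanyl group or an amine in place of methylsulfanyl on that aromatic carbon would give a lower number stays open.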